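Methoxy addition compared on two related cores

This account rests on a few compounds, and the source may have more. Where it says the series, first, only, none or still open, it means among the compounds named here.

Measured so far in a functional assay on A549 cells (Homo sapiens) for antiproliferative activity, read by sulforhodamine B assay, with a stated time of 48 h; a higher number here means a weaker inhibitor, a lower number a stronger inhibitor:

- compound 1 `COc1ccc(/C=C/C(=O)c2ccccc2-c2ccc(F)cc2)cc1`: 140 nM
- compound 2 `COc1ccc(/C=C/C(=O)c2ccccc2-c2ccc(F)cc2)cc1OC`: 440 nM
- compound 3 `COc1ccc(C(=O)/C=C/c2ccccc2-c2ccc(F)cc2)cc1OC`: 7500 nM

Compound 1 and compound 2 share a core and differ by one change, (methoxy in place of hydrogen on an aromatic carbon). That change gave a 3.1-fold higher number from compound 1 to compound 2 (0.50 log units; beyond the scatter), so the added methoxy cost some potency on this core.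

Compound 3 carries a different core, and the difference between the two cores is not broken down here. What the values show is that compound 3 stands highest of the three, with compound 2 nearest and compound 1 furthest.

Compound 4 `COc1cc(C(=O)/C=C/c2ccccc2-c2ccc(F)cc2)cc(OC)c1OC` is not yet measured. It arises from compound 3 by methoxy in place of hydrogen on an aromatic carbon. Compared with the change from compound 1 to compound 2, the place line for this one adds that the entering group is also meta to a methoxy group, so it is the same kind of change rather than the same change.

For the measured compounds named here, on the single precedent, the expectation for the step from compound 3 to compound 4 in this assay is a 2.3-fold higher number from compound 3 to compound 4 (0.36 log units; beyond the scatter), because a 3.1-fold higher number from compound 1 to compound 2 (0.50 log units; beyond the scatter) is the only measure of this kind of change, and the new core gives no separate guide. The wider range reflects that the surroundings of the place differ and that compound 3 already lies high. The estimate for compound 4 is 17000 nM, expected between 5000 nM and 60000 nM.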

Compound 4, half-maximal inhibitory concentration: 2200 nM
Compound 4: the middle estimate sits 7.7-fold (0.89 log units) above what was measured; measured number below the stated range.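

In this assay, methoxy in place of hydrogen on an aromatic carbon gave a 3.4-fold lower number from compound 3 to compound 4 (0.53 log units; beyond the scatter), so on the core of compound 3 the added methoxy gained potency, whereas on the core of compound 1 it cost potency. The two steps run in opposite directions, and the gap between them exceeds what scatter would account for, so the direction of this change did not carry from one core to the other in this series: the same change on two cores in this assay, a 3.1-fold higher number (0.50 log units; beyond the scatter) from compound 1 to compound 2 and a 3.4-fold lower number (0.53 log units; beyond the scatter) from compound 3 to compound 4, 11-fold (1.03 log units) apart, beyond the scatter of two such steps. With one step on each core, these data do not show whether the reversal belongs to the core itself or to the surroundings of the place, where the entering group on compound 4 is ortho to a methoxy group and meta to a methoxy group, and they give no cause for it.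

The compounds shown leave open whether a different group at the same place on the core of compound 3, such as a hydroxyl, an ethoxy chain or an amine, would follow the methoxy step. They also leave open whether a further pair on either core would give a step of the same direction and size.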